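Moving the nitrile around the phenyl ring on a triazole core

The source may report more compounds than this note shows. Statements on the series, on what has been measured and on what is new or still open speak of the compounds shown alone.

Compound 3 `CC1(C)[C@H]2CC[C@]1(C)N(Cc1cn(-c3ccc(Br)cc3)nn1)C(=O)C2` gives 450 nM in a functional assay on SGC-7901 cells (Homo sapiens) for inhibition, read by MTT assay, with a stated time of 24 h (on this read-out higher numbers stand for weaker inhibition and lower numbers for stronger inhibition), the highest of the three numbers here, though its gaps to compound 1 `COc1ccccc1-n1cc(CN2C(=O)C[C@@H]3CC[C@@]2(C)C3(C)C)nn1` at 280 nM and compound 2 `CC1(C)[C@H]2CC[C@]1(C)N(Cc1cn(-c3ccccc3C#N)nn1)C(=O)C2` at 260 nM both fall within the usual scatter. Compound 4 `CC1(C)[C@H]2CC[C@]1(C)N(Cc1cn(-c3cccc(C#N)c3)nn1)C(=O)C2` carries the change (3-cyanophenyl in place of 4-bromophenyl on an aromatic nitrogen). Within the data shown here, two measured steps bear on this swap of the aryl group: a 1.7-fold higher number from compound 2 to compound 3 (0.24 log units; within the scatter) and a 1.6-fold higher number from compound 1 to compound 3 (0.21 log units; within the scatter), both within the scatter. Since compound 4 returns a nitrile to the phenyl ring, its number is expected to sit near that of compound 2, yet no step beyond the scatter is expected. Compound 4 is therefore estimated at 300 nM, with a range from 150 nM to 600 nM, meaning an expected step of a 1.5-fold lower number from compound 3 to compound 4 (0.18 log units; within the scatter).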

Compound 4, half-maximal inhibitory concentration: 250 nM
Compound 4: middle estimate off by 1.2-fold (0.08 log units), on the high side; the measured number falls inside the stated range.
By their numbers in this assay, from the lowest: compounds 4, 2, 1 and 3 (each within the scatter of the next).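

In this assay, moving the nitrile from the 2-cyanophenyl to the 3-cyanophenyl group gives no step beyond the scatter (a 1.0-fold lower number from compound 2 to compound 4 (0.02 log units; within the scatter)). The swaps from the other two aryl groups on this aromatic nitrogen also stay within it (a 1.8-fold lower number from compound 3 to compound 4 (0.26 log units; within the scatter); a 1.1-fold lower number from compound 1 to compound 4 (0.05 log units; within the scatter)), so all four groups tested here read alike. No measured evidence bears on why this is so. Still open, from the compounds shown here alone, is whether an amine or a carboxylic acid on the phenyl ring, or a longer chain in place of that ring, would give a step beyond the scatter.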